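From fluoro to ethoxy: a step starting from a limit

The source may report more compounds than this note shows. Statements on the series, on what has been measured and on what is new or still open speak of the compounds shown alone.

Measured in a functional assay on Vero cells (Chlorocebus sabaeus) for inhibition; on this read-out higher numbers stand for weaker inhibition and lower numbers for stronger inhibition:
- Compound 1 `CSc1ccc(Cn2cnc3c(-c4ccco4)ncnc32)cc1` gives 6.9 ug/mL as a number
- Compound 2 `Clc1cccc(Cn2cnc3c(-c4ccco4)ncnc32)c1` gives > 10 ug/mL as a limit
- Compound 3 `Fc1ccc(Cn2cnc3c(-c4ccco4)ncnc32)cc1` gives > 10 ug/mL as a limit

Compound 3 sits at the limit of > 10 ug/mL in this assay, at which 2 of the 3 values shown sit, and so has no exact number. Compound 4 `CCOc1ccc(Cn2cnc3c(-c4ccco4)ncnc32)cc1` carries ethoxy in place of fluoro on an aromatic carbon, counted as ethoxy in place of fluoro on an aromatic carbon here. The closest guide is an at least 1.4-fold higher number from compound 1 to compound 3 (0.16 log units; that floor lies within the scatter) and it also swaps the group on an aromatic carbon. By contrast, a step that the two limits leave unreadable from compound 2 to compound 3 gives no usable size. For the measured compounds named here, only a modest move towards stronger inhibition is expected in this assay, resting on compound 1 at 6.9 ug/mL as the one exact value available. A result at the limit is also quite possible for compound 4. The estimated change is an at least 1.2-fold lower number from compound 3 to compound 4 (0.09 log units; that floor lies within the scatter) overall. For compound 4 the estimated value is 8 ug/mL with an expected range from 3.5 ug/mL to 18 ug/mL in this test.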

Compound 4, half-maximal inhibitory concentration: 37.4 ug/mL
Beside the measured number, compound 4's estimate is 4.7-fold (0.67 log units) below it, outside the stated range (above it).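

In this assay, swapping methylsulfanyl for ethoxy on the aromatic carbon para to a large group gives a 5.4-fold higher number from compound 1 to compound 4 (0.73 log units; beyond the scatter), a change that lies beyond the usual scatter of repeat measurements. For the compounds shown here, this gives the series a second exact number, so a size can be put on a change of group at this position for the first time, and here that change goes towards weaker inhibition. The step between compound 3 and compound 4 cannot be read, because compound 3 has only a limit and no exact number: the limit of > 10 ug/mL in this assay, at which 2 of the 4 values shown sit.

The compounds shown leave open whether methoxy, with a shorter chain on the same oxygen, or an amine or a carboxylic acid at this position would give stronger or weaker inhibition. They also leave open whether an exact number for compound 3 would place fluoro nearer to ethoxy or to methylsulfanyl.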